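This account rests on a few compounds, and the source may have more. Where it says the series, first, only, none or still open, it means among the compounds named here.

In a functional assay on BGC-823 cells (Homo sapiens) for inhibition, read by MTT assay, with a stated time of 72 h (a higher number here means a weaker inhibitor, a lower number a stronger inhibitor), compound 1 `Cc1cc(N2CC[C@@H](C)[C@@H](N(C)c3ncnc4[nH]ccc34)C2)n2nc(SCc3ccccc3)nc2n1` gives 14400 nM, and compound 2 `Cc1cc(N2CC[C@@H](C)[C@@H](N(C)c3ncnc4[nH]ccc34)C2)n2nc(SCc3ccccc3Br)nc2n1` gives 81100 nM. Compound 3 `Cc1cc(N2CC[C@@H](C)[C@@H](N(C)c3ncnc4[nH]ccc34)C2)n2nc(SCc3csc4ccc(Cl)cc34)nc2n1` stands at > 100000 nM, which is a limit and not a number, as the limit of > 100000 nM in this assay, at which 1 of the 3 values shown sits, records. Compound 4 `Cc1cc(N2CC[C@@H](C)[C@@H](N(C)c3ncnc4[nH]ccc34)C2)n2nc(SCc3ccc(F)c(Cl)c3)nc2n1` differs from it by 3-chloro-4-fluorophenyl in place of 5-chloro-1-benzothiophen-3-yl on a saturated chain carbon bound to a sulfur.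

Within the data shown here, three measured steps bear on this. Bromo in place of hydrogen on an aromatic carbon gave a 5.6-fold higher number from compound 1 to compound 2 (0.75 log units; beyond the scatter). The 5-chloro-1-benzothiophen-3-yl group gave an at least 6.9-fold higher number from compound 1 to compound 3 (0.84 log units; beyond the scatter), and also an at least 1.2-fold higher number from compound 2 to compound 3 (0.09 log units; that floor lies within the scatter). Compound 4 keeps a halogen-bearing phenyl, as compound 2 does at 81100 nM, so a modest move toward a lower number is expected. The expected step is an at least 2.2-fold lower number from compound 3 to compound 4 (0.34 log units; beyond the scatter). For compound 4 the estimated value is 45000 nM, with an expected range of 14000 nM to 100000 nM.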

Compound 4, half-maximal inhibitory concentration: 98900 nM
Compound 4: middle estimate off by 2.2-fold (0.34 log units), on the low side, within the range that was stated.
By their numbers in this assay, from the lowest: compound 1; then compounds 2 and 4 (each within the scatter of the next). At a limit, above all of these: compound 3.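

On the saturated chain carbon bound to a sulfur, 3-chloro-4-fluorophenyl in place of 2-bromophenyl gives a 1.2-fold higher number from compound 2 to compound 4 (0.09 log units; within the scatter), so the two groups cannot be told apart. Against plain phenyl the new group gives a 6.9-fold higher number from compound 1 to compound 4 (0.84 log units; beyond the scatter), so each halogen-bearing group shown stays on the higher-number side of the unsubstituted ring. In place of 5-chloro-1-benzothiophen-3-yl the new group gives a number no higher from compound 3 to compound 4 (the limit leaves the size open), and the size of this step cannot be read, because compound 3 is held only at a limit: the limit of > 100000 nM in this assay, at which 1 of the 4 values shown sits.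

As far as these compounds go, whether an amine or a carboxylic acid on the phenyl, or a longer chain to the sulfur, would take the number under that of compound 1, at 14400 nM, remains open.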